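A Methoxycarbonyl Group Added to a Weak Inhibitor

The compounds below may be only part of what the source reports. "The series", "measured", "known", "first", "only" and "open" are said of these compounds alone.

Of the compounds shown here, two have been tested in a functional assay on KB cells (Homo sapiens) for inhibition; a higher number here means a weaker inhibitor, a lower number a stronger inhibitor. Compound 1 `CC(C)c1ccc(C(c2ccccc2)c2ccc(C(C)C)cc(=O)c2O)c(O)c(=O)c1` gives 0.3 ug/mL, while compound 2 `Oc1ccccc1C1OCCc2ccccc21` gives 20.5 ug/mL. Of the two numbers, compound 2 has the higher one, so compound 2 is the weaker inhibitor, and the gap between the two compounds lies far beyond the usual scatter of this assay. Compound 1 and compound 2 share no common scaffold, so their difference cannot be traced to any single structural change.

Compound 3 `COC(=O)c1ccc(O)c(C2OCCc3ccccc32)c1` has not yet been measured. It keeps the whole of compound 2 and differs in one place: methoxycarbonyl in place of hydrogen on an aromatic carbon. Among the measured compounds shown here, no measured pair here shows what such an addition does in this assay, so nothing in the data points to a strong effect in either direction. A step within the scatter, or at most a small weakening, is the most reasonable expectation. Compound 3 is therefore expected to give 22 ug/mL, within a range from 6 ug/mL to 70 ug/mL. This corresponds to an expected step of a 1.1-fold higher number from compound 2 to compound 3 (0.03 log units; within the scatter) that should stay close to the usual scatter.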

Compound 3, concentration for 50% inhibition: > 100 ug/mL
Compound 3: only a limit was reported; the forecaster's own chance of this, stated with the estimate: 15%; middle value at least 4.5-fold (0.65 log units) from the limit.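

In this assay, among the compounds shown here, methoxycarbonyl in place of hydrogen on this aromatic carbon, para to a hydroxy group and meta to a large group, is the first change here that can be read on its own, and it gives an at least 4.8-fold higher number from compound 2 to compound 3 (0.68 log units; beyond the scatter). Compound 3 carries only a limit of the assay, > 100 ug/mL, and not a number. This position is therefore not indifferent to the change: this one addition to compound 2 weakens inhibition beyond the scatter, while the full size of the loss stays unfixed: the limit of > 100 ug/mL in this assay, at which 1 of the 3 values shown sits.

Methoxycarbonyl is the only group on this carbon among the compounds shown, so it remains open whether the loss belongs to this particular group or would follow any addition at this place. From the compounds shown here alone, how a carboxylic acid, an amine or a small methyl group on the same carbon would compare with hydrogen and with methoxycarbonyl is also open, as is whether the same addition elsewhere on this ring would weaken inhibition to a similar degree.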